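The compounds below may be only part of what the source reports. "The series", "measured", "known", "first", "only" and "open" are said of these compounds alone.

Measured compounds:
compound 1 `COC(=O)/C=C/c1cccc(NC(=O)C2CCCCC2)c1`, > 1000 nM;
compound 2 `COC(=O)/C=C/c1cccc(N(C(=O)C2CCCCC2)c2ccc3ccccc3c2)c1`, 680 nM;
compound 3 `COC(=O)/C=C/c1cccc(N(Cc2cccc(Br)c2)C(=O)C2CCCCC2)c1`, > 1000 nM.

In an assay on isolated protein with Bile acid receptor (Homo sapiens) as the target (on this read-out lower numbers stand for an effect already at smaller amounts and higher numbers for an effect only at larger amounts of compound), compound 3 gives > 1000 nM, which is a limit of the assay and not a number. Compound 1 also sits at a limit, (the limit of > 1000 nM in this assay, at which 2 of the 3 values shown sit). Only compound 2 gives a number in this assay, 680 nM. Compound 4 `COC(=O)/C=C/c1cccc(N(Cc2cc(OC)cc(OC)c2)C(=O)C2CCCCC2)c1` differs from compound 3 in one place: 3,5-dimethoxyphenyl in place of 3-bromophenyl on a saturated chain carbon bound to an amide-type nitrogen. For the measured compounds named here, the measured steps reaching compound 3 are an at least 1.4-fold higher number from compound 2 to compound 3 (0.16 log units; that floor lies within the scatter) and a step that the two limits leave unreadable from compound 1 to compound 3; neither one alters the substituent of the 3-bromobenzyl group, so no measured step speaks directly to the exchange of bromine for two methoxy groups. Compound 4 is therefore expected to stay close to the limit, with an expected step that the limit leaves unreadable from compound 3 to compound 4. The estimate for compound 4 in this assay is 1500 nM, ranging from 500 nM to 5000 nM.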

Compound 4, half-maximal effective concentration: 606 nM
Compound 4: the middle estimate sits 2.5-fold (0.39 log units) above what was measured; measured number inside the range.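

Exchanging 3-bromophenyl for 3,5-dimethoxyphenyl on a saturated chain carbon bound to an amide-type nitrogen gives an at least 1.6-fold lower number from compound 3 to compound 4 (0.21 log units; that floor lies within the scatter) in this assay. This shows that a substituted benzyl group on this nitrogen can give a readable number, which compound 3 did not. The size of the step remains only a floor because compound 3 sits at a limit and not a number: the limit of > 1000 nM in this assay, at which 2 of the 4 values shown sit.

The compounds shown leave open whether a single methoxy group would also give a number in this assay. They also leave open how an amine or a carboxylic acid on this phenyl ring would behave.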